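Sulfonamide Out, Tetrazole In: One Change, One Expectation

The source may report more compounds than this note shows. Statements on the series, on what has been measured and on what is new or still open speak of the compounds shown alone.

Of the compounds shown here, three have been measured in a functional assay for antagonist activity at transient receptor potential cation channel subfamily V member 1 (Homo sapiens), read by FLIPR; a higher number here means a weaker inhibitor, a lower number a stronger inhibitor. Compound 1 `O=C(Nc1ccccc1)c1ccc(-c2ncccc2C(F)(F)F)cc1` reaches only a limit of that assay, giving > 4000 nM; this is the limit of > 4000 nM in this assay, at which 1 of the 3 values shown sits. Compound 2 `Cc1cccnc1-c1ccc(C(=O)Nc2ccc(C(F)(F)F)cc2)cc1` gives 65 nM in this assay. Compound 3 `CC(C)(C)c1ccc(NC(=O)c2ccc(-c3ncccc3NS(C)(=O)=O)cc2)cc1` gives 152 nM, the higher of the two numbers, and its gap to compound 2 lies beyond the usual scatter. Compound 4 `CC(C)(C)c1ccc(NC(=O)c2ccc(-c3ncccc3-c3nn[nH]n3)cc2)cc1` has not yet been measured. It differs from compound 3 in one place: 2H-tetrazol-5-yl in place of methanesulfonamido on an aromatic carbon. Among the measured compounds shown here, no measured pair shows a change of this kind, so the expectation rests on compound 3 alone. With 2H-tetrazol-5-yl in place of methanesulfonamido, the number is expected to rise somewhat, a step estimated as a 2.6-fold higher number from compound 3 to compound 4 (0.42 log units; beyond the scatter). Compound 4 is accordingly expected to give 400 nM, within a range from 100 nM to 1600 nM.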

Compound 4, half-maximal inhibitory concentration: > 4000 nM
Compound 4 gave a limit, no number; the forecaster's own chance of this, stated with the estimate: 20%; at least 10-fold (1.00 log units) between middle value and limit.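

On this aromatic carbon, two atoms from the ring nitrogen, 2H-tetrazol-5-yl in place of methanesulfonamido gives an at least 26-fold higher number from compound 3 to compound 4 (1.42 log units; beyond the scatter) in this assay. This is the first change at this place among the compounds shown, and the two groups are equal in heavy-atom count, so that count alone does not keep the activity of compound 3. The result for compound 4 is a limit, not a number: the limit of > 4000 nM in this assay, at which 2 of the 4 values shown sit.

As far as these compounds go, whether a carboxylic acid or an amine on this carbon would give a number within the range of the assay remains open. So does the true size of the step.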